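The source may hold more compounds than are shown below. What is called first, only, known or untested is meant among the compounds shown, and "the series" means these compounds.

Compound 2, with the structure `CCCCc1ccc(/C=C/C(=O)Nc2ccc3c(c2)OCCO3)cc1`, was tested in a functional assay on CHO cells for inhibition of transient receptor potential cation channel subfamily V member 1 (Homo sapiens); a higher number here means a weaker inhibitor, a lower number a stronger inhibitor. Within the data shown here, compound 2 gives 360 nM, and this is the higher of the two numbers measured so far. Among the measured compounds shown here, the other measured compound, compound 1, with the structure `CC(C)(C)c1ccc(/C=C/C(=O)Nc2ccc3c(c2)NCCC3)cc1`, gives 36 nM in this assay; compound 1 differs from compound 2 in more than one place, so the two values show only that compound 1 is the stronger inhibitor of the pair, by a margin beyond the scatter.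

Compound 3, with the structure `O=C(/C=C/c1ccc(C(F)(F)F)cc1)Nc1ccc2c(c1)OCCO2`, has not yet been measured. It differs from compound 2 in one place: trifluoromethyl in place of butyl on an aromatic carbon. For the measured compounds named here, no comparison between measured compounds tells what such a swap does in this assay, so no firm direction can be read from the data. The expectation for the step from compound 2 to compound 3 is a modest move toward stronger inhibition, a 2.0-fold lower number from compound 2 to compound 3 (0.30 log units; within the scatter), which may well lie within the scatter. Compound 3 is therefore estimated to give 180 nM, with a range from 45 nM to 700 nM.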

Compound 3, half-maximal inhibitory concentration: 46 nM
Estimate against measurement, compound 3: 3.9-fold (0.59 log units) above; the measured number falls inside the stated range.
By their numbers in this assay, from the lowest: compounds 1 and 3 (each within the scatter of the next); then compound 2.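

In this assay, putting trifluoromethyl in place of butyl on the aromatic carbon para to a large group gives a 7.8-fold lower number from compound 2 to compound 3 (0.89 log units; beyond the scatter) on the same core, so the number clearly depends on which group sits at this position. Butyl and trifluoromethyl both have 4 heavy atoms, and neither has a hydrogen-bond donor or acceptor, so these counts alone do not set the number here, as this pair differs beyond the scatter despite matching on all of them. Nothing measured in this set explains the difference between the two groups.

The compounds shown leave open whether the step comes from losing the carbon chain or from gaining the fluorine atoms, as this single swap changes both at once. A methyl group, a chlorine atom or a longer chain such as hexyl at this position on the same core would help to separate those two readings, and for now the response of this position rests on one pair of compounds.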